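Adding a Methoxy to the Phenyl Ring of Compound 3

A few compounds are considered here, and "the series" means these few. Any claim that something is new, unique, unknown or untested is made for them only; others in the source may bear on it.

Measured so far:
Compound 1 `COc1cc(/C=C/C(=O)c2cccc(-n3cc(-c4ccccc4)[nH]c3=O)c2)ccc1O` gives 1590 nM in a functional assay on SK-MEL-5 cells (Homo sapiens) for inhibition; a lower number here means a stronger inhibitor of growth, a higher number a weaker inhibitor of growth.
Compound 2 `O=C(/C=C/c1cccc(O)c1)c1cccc(-n2cc(-c3ccccc3)[nH]c2=O)c1` gives 3180 nM in this assay.
Compound 3 `COc1cc(/C=C/C(=O)c2cccc(-n3cc(-c4ccccc4)[nH]c3=O)c2)cc(OC)c1OC` gives 1400 nM in this assay.

Compound 3 has the lowest of the three numbers, but compound 1 lies within the scatter of it, so the two cannot be told apart; only compound 2 stands beyond the scatter from compound 3.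

Compound 4 `COc1ccc(-c2cn(-c3cccc(C(=O)/C=C/c4cc(OC)c(OC)c(OC)c4)c3)c(=O)[nH]2)cc1` differs from compound 3 in one place: methoxy in place of hydrogen on an aromatic carbon. Going by the values given here, the only measured single-step change, a 2.0-fold higher number from compound 1 to compound 2 (0.30 log units; within the scatter), concerns the other aromatic ring, the one on the double-bonded chain, not the phenyl ring altered here, and it moved the number only within the scatter. Among the compounds with values here, no measured step touches the phenyl ring on the shared core, so there is no direct precedent. On that basis the step from compound 3 to compound 4 is expected to be small, no change at the digits printed from compound 3 to compound 4 (within the scatter), with no clear direction.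

Compound 4 is therefore estimated at 1400 nM, within a range of 500 nM to 4000 nM.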

Compound 4, concentration for 50% growth inhibition: 2030 nM
Compound 4: the middle estimate sits 1.5-fold (0.16 log units) below what was measured; low and high end bracket the measured number.
By their numbers in this assay, from the lowest: compounds 3, 1, 4 and 2 (each within the scatter of the next, the first and the last beyond it).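

Going by these compounds alone, this is the first measured step on the phenyl ring of the shared core, and in this assay methoxy in place of hydrogen, para to a large group, gives a 1.5-fold higher number from compound 3 to compound 4 (0.16 log units; within the scatter) and no more. So this position can carry a methoxy without a difference that stands out from the scatter, at least with the trimethoxy-substituted ring of compound 3 on the other end of the molecule. Nothing measured here bears on why the step is this size.

One group at one place cannot show how much this position allows overall. On these data alone, whether an amine, a carboxylic acid or a longer chain such as butoxy would stay as close to compound 3, or move the number beyond the scatter, remains open.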